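Ester chain extension on the methyl ester of compound 1

The source may hold more compounds than are shown below. What is called first, only, known or untested is meant among the compounds shown, and "the series" means these compounds.

Compound 1 `CO/C(O)=C1\C(C)=NC(C)=C([N+](=O)[O-])C1c1cccnc1` stands at the highest number of the three compounds measured in a functional assay (cardiac atrium) for agonist activity, with Cavia porcellus as the target (on this read-out higher numbers stand for an effect only at larger amounts of compound and lower numbers for an effect already at smaller amounts), giving 70000 nM. Compound 2 `CO/C(O)=C1\C(C)=NC(C)=C([N+](=O)[O-])C1c1ccncc1` gives 48500 nM; the step of a 1.4-fold lower number from compound 1 to compound 2 (0.16 log units; within the scatter) lies within the scatter. Compound 3 `CC1=NC(C)=C([N+](=O)[O-])C(c2ccccn2)/C1=C(\O)OC1CCCC1` gives 19800 nM, a lower number than compound 1 beyond the scatter, but compound 3 differs from compound 1 in two places, the ester group and the pyridinyl group, so no single change can be read from that pair.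

Compound 4 `COCCO/C(O)=C1\C(C)=NC(C)=C([N+](=O)[O-])C1c1cccnc1` is not yet measured. It differs from compound 1 by methoxymethyl in place of hydrogen on a saturated chain carbon bound to an oxygen on an unsaturated carbon. Among the measured compounds shown here, no measured step changes the ester group alone, so nothing in the data bears directly on this change; the only larger ester, in compound 3, is confounded with the ring change. The expectation is therefore a small step, if any, toward a lower number, near the scatter: compound 4 is expected to give 45000 nM, with a range from 15000 nM to 120000 nM. The expected step of a 1.6-fold lower number from compound 1 to compound 4 (0.19 log units; within the scatter) rests on the absence of direct evidence rather than on a measured trend.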

Compound 4, half-maximal effective concentration: 49400 nM
Beside the measured number, compound 4's estimate is 1.1-fold (0.04 log units) below it, within the range that was stated.
By their numbers in this assay, from the lowest: compound 3; then compounds 2, 4 and 1 (each within the scatter of the next).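

The ester group now has a reading of its own with the pyridin-3-yl group held fixed: in this assay, methoxymethyl in place of hydrogen on a saturated chain carbon bound to an oxygen on an unsaturated carbon gives a 1.4-fold lower number from compound 1 to compound 4 (0.15 log units; within the scatter). This position therefore accepts the methoxymethyl extension with no change that can be told from the scatter, and the pyridinyl change in a 1.4-fold lower number from compound 1 to compound 2 (0.16 log units; within the scatter) also stays within it. Nothing available offers an explanation for this result.

In this assay, the lower number of compound 3, 19800 nM, still cannot be assigned to either its ester group or its pyridinyl group. Also open, as far as these compounds go, is how an ester chain carrying an amine or a carboxylic acid, or a longer chain, would read at this position.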